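Swapping an amine for pyrrole on a phenyl-capped imide

The source may report more compounds than this note shows. Statements on the series, on what has been measured and on what is new or still open speak of the compounds shown alone.

Of the compounds shown here, three built on one shared core have been measured in a functional assay on KB cells (Homo sapiens) for antiproliferative activity, read by MTT assay, with a stated time of 48 h; on this read-out higher numbers stand for weaker inhibition and lower numbers for stronger inhibition. Within the data shown here, compound 2 `CN(C)CCCn1nc(C2=C(c3cn(C)c4ccccc34)C(=O)N(c3ccccc3)C2=O)c2cccnc21` gives 14100 nM, the only plain number among the three. Compound 3 `CN(C)CCCn1nc(C2=C(c3cn(C)c4ccccc34)C(=O)NC2=O)c2cccnc21` reaches only the limit > 100000 nM, which is a limit and not a number. Compound 1 `Cn1cc(C2=C(c3nn(CCCn4cccc4)c4ncccc34)C(=O)NC2=O)c2ccccc21` likewise stops at the limit > 100000 nM. From compound 3 to compound 2 the change is phenyl in place of hydrogen on an amide-type nitrogen in a ring, and the reverse step is an at least 7.0-fold higher number from compound 2 to compound 3 (0.85 log units; beyond the scatter). The change 1H-pyrrol-1-yl in place of dimethylamino on a saturated chain carbon, three bonds along the chain from an aromatic nitrogen gives a step that the two limits leave unreadable from compound 3 to compound 1, since both values sit at the limit of > 100000 nM in this assay, at which 2 of the 3 values shown sit. Compound 4 `Cn1cc(C2=C(c3nn(CCCn4cccc4)c4ncccc34)C(=O)N(c3ccccc3)C2=O)c2ccccc21` carries the same change applied to compound 2, (1H-pyrrol-1-yl in place of dimethylamino on a saturated chain carbon, three bonds along the chain from an aromatic nitrogen); the two place descriptions match word for word. The step is expected to be a 1.8-fold higher number from compound 2 to compound 4 (0.25 log units; within the scatter), resting only on compound 2 at 14100 nM, as the earlier step is unreadable. Compound 4 is estimated at 25000 nM, between 8000 nM and 100000 nM.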

Compound 4, half-maximal inhibitory concentration: > 100000 nM
Compound 4: only a limit was reported; the forecaster's own chance of this, stated with the estimate: 25%; middle value at least 4.0-fold (0.60 log units) from the limit.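

In this assay, putting 1H-pyrrol-1-yl in place of dimethylamino on the core with phenyl on the ring nitrogen gives an at least 7.0-fold higher number from compound 2 to compound 4 (0.85 log units; beyond the scatter). Compound 4 gives > 100000 nM, a limit and not a number, so the step has a minimum size but no known full size. Whether the change does the same on the core without phenyl stays unknown, and the steps from compound 3 to compound 1 and from compound 1 to compound 4 cannot be read, since both ends of each sit at one limit: the limit of > 100000 nM in this assay, at which 3 of the 4 values shown sit.

Still open, as far as these compounds go, is whether another amine at the chain end, such as piperidine or morpholine, would match compound 2 at 14100 nM. From the compounds shown here alone, a longer chain carrying dimethylamino is equally open.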